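A few compounds are considered here, and "the series" means these few. Any claim that something is new, unique, unknown or untested is made for them only; others in the source may bear on it.

Measured compounds:
Compound 1 `C=C1C(=O)[C@]23C[C@@]1(O)CC[C@H]2c1ccc(O)c(C)c1[C@@H]3Cn1cc(-c2ccccn2)nn1` — 2240 nM
Compound 2 `C=C1C[C@]23C[C@@]1(O)CC[C@@H]2c1cccc(C)c1[C@@H]3Cn1cc(-c2ccc(OC)cc2)nn1` — > 20000 nM

In a functional assay on MCF7 cells (Homo sapiens) for cytotoxicity, read by MTT assay, with a stated time of 4 days (a higher number here means a weaker inhibitor, a lower number a stronger inhibitor), compound 1 gives 2240 nM. Compound 2 gives only a limit of the assay, > 20000 nM, so no number is known for it. Compound 2 stands at the limit of > 20000 nM in this assay, at which 1 of the 2 values shown sits. Going by the values given here, compound 1 and compound 2 differ in more than one place, so their two values show only that compound 1 has a number where compound 2 has none.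

Compound 3 `C=C1C[C@]23C[C@@]1(O)CC[C@@H]2c1cccc(C)c1[C@@H]3Cn1cc(-c2ccccn2)nn1` is not yet measured. It differs from compound 2 in a single place: pyridin-2-yl in place of 4-methoxyphenyl on an aromatic carbon — pyridin-2-yl in place of 4-methoxyphenyl on an aromatic carbon. Among the compounds with values here, no measured pair differing in one place shows how large such a swap is in this assay, so the direction of the step is open, with a modest gain thought somewhat more likely than none. Compound 3 is therefore estimated at 15000 nM, within 4000 nM to 40000 nM. This estimate means an expected step of an at least 1.3-fold lower number from compound 2 to compound 3 (0.12 log units; that floor lies within the scatter).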

Compound 3, half-maximal inhibitory concentration: > 20000 nM
Compound 3: no number, only a limit (the forecaster's own chance of this, stated with the estimate: 45%); at least 1.3-fold (0.12 log units) between middle value and limit.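

Compound 2 and compound 3 both stop at a limit of the assay rather than a number, so no step between them can be read: the limit of > 20000 nM in this assay, at which 2 of the 3 values shown sit.

The compounds shown leave open how far each lies past that limit, and whether pyridin-2-yl in place of 4-methoxyphenyl changes anything at all.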